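This account rests on a few compounds, and the source may have more. Where it says the series, first, only, none or still open, it means among the compounds named here.

Compound 1, `CN1CCN(c2nc3ccccc3n2CCOCCO)CC1`: in a functional assay on ileum for inhibition of histamine H1 receptor (Cavia porcellus) (a lower number here means a stronger inhibitor, a higher number a weaker inhibitor), compound 1 gives 42 nM.
Compound 2, `CN1CCN(c2nc3ccccc3[nH]2)CC1`: in this assay compound 2 gives > 3000 nM, which is a limit of the assay and not a number.

Compound 2 therefore stands at the weak end of what has been measured here, sitting at the limit of > 3000 nM in this assay, at which 1 of the 2 values shown sits, while compound 1 has a proper number. The change that leads on from compound 2 is 2-methoxyethyl in place of hydrogen on an aromatic nitrogen, giving compound 3, `COCCn1c(N2CCN(C)CC2)nc2ccccc21`. Among the compounds with values here, one measured step bears on this move: an at least 71-fold higher number from compound 1 to compound 2 (1.85 log units; beyond the scatter), in which a chain of this kind was taken off the same ring nitrogen. Putting a chain of related build back onto that nitrogen is expected to undo much of that loss, so a large step toward a lower number in this assay is expected, as an at least 30-fold lower number from compound 2 to compound 3 (1.47 log units; beyond the scatter). For compound 3 the expected value in this assay is estimated at 100 nM, with a likely range from 30 nM to 600 nM.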

Compound 3, half-maximal inhibitory concentration: 13 nM
Estimate against measurement, compound 3: 7.7-fold (0.89 log units) above; the measured number lies below the stated range.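

Placing 2-methoxyethyl on the aromatic nitrogen in place of hydrogen gives an at least 230-fold lower number from compound 2 to compound 3 (2.36 log units; beyond the scatter) in this assay, so the recovery at this nitrogen does not need the full 2-(2-hydroxyethoxy)ethyl chain of compound 1. The size of that step is only a bound, and not an exact figure, because compound 2 has a limit of the assay and not a number: the limit of > 3000 nM in this assay, at which 1 of the 3 values shown sits.

Trimming the chain also brings a further gain, as hydrogen in place of hydroxymethyl on the chain gives a 3.2-fold lower number from compound 1 to compound 3 (0.51 log units; beyond the scatter), a modest change but one beyond the scatter, which shows that the hydroxyl-bearing part of the longer chain is not required for inhibition in this assay.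

The compounds shown leave open whether the oxygen in the chain matters at all, a question that a plain butyl chain on the same nitrogen would answer. They also leave open how short the chain can become while keeping this strength, as with a methyl group, and how a chain ending in an amine or a carboxylic acid would behave in this assay.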